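A few compounds are considered here, and "the series" means these few. Any claim that something is new, unique, unknown or untested is made for them only; others in the source may bear on it.

Measured so far in a physicochemical assay for solubility (on this read-out lower numbers stand for lower solubility and higher numbers for higher solubility), each value a limit of the assay and not a number:

Compound 1 `CNC(=O)c1cc(C(=O)N[C@H]2[C@@H]3COC[C@@H]32)cc2c1OC[C@H]2c1cccnc1`: >= 104 ug/mL
Compound 2 `CNC(=O)c1cc(C(=O)NC2CC2)cc2c1OC[C@H]2c1cccc2[nH]ccc12`: >= 142 ug/mL
Compound 3 `CNC(=O)c1cc(C(=O)N[C@H]2[C@@H]3COC[C@@H]32)cc2c1OC[C@H]2c1cccc(OC)c1`: >= 186 ug/mL

Compound 3 is reported only as a limit, >= 186 ug/mL. The three limits therefore give no exact solubility for any of these compounds, and they do not rank them.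

Compound 4 `CNC(=O)c1cc(C(=O)N[C@H]2[C@@H]3COC[C@@H]32)cc2c1OC[C@H]2c1cccc2[nH]ccc12` keeps the rest of compound 3 and puts 1H-indol-4-yl in place of 3-methoxyphenyl on a saturated ring carbon.

For the measured compounds named here, only one measured step bears on this site, a step that the two limits leave unreadable from compound 1 to compound 3. It offers no size to carry over to the new change. The closest evidence is compound 2, which carries the same 1H-indol-4-yl group on a different amide. Compound 2 is also reported only as a limit, >= 142 ug/mL. That limit gives no sign of a poorly soluble compound, though it cannot give a size or direction for the change in this assay.

The expectation is therefore for no step beyond the scatter, and for another result reported as a limit. The expected step is an at least 1.2-fold lower number from compound 3 to compound 4 (0.09 log units; that floor lies within the scatter). For compound 4 the estimated value is 150 ug/mL, with an expected range from 60 ug/mL to 300 ug/mL.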

Compound 4, solubility: >= 171 ug/mL
Compound 4: a limit, no number; the forecaster's own chance of this, stated with the estimate: 70%; at least 1.1-fold (0.05 log units) between middle value and limit.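

In this assay compound 4 gives >= 171 ug/mL, a limit and not a number. For the compounds shown here, compound 1, compound 2 and compound 3 also carry limits, and no step from any of them to compound 4 can be read. The compounds shown leave open the actual solubility of all four, and whether 1H-indol-4-yl in place of 3-methoxyphenyl changes it.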